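Removing the phenyl ether from a sulfonamide series

A few compounds are considered here, and "the series" means these few. Any claim that something is new, unique, unknown or untested is made for them only; others in the source may bear on it.

Compound 1 `COc1cc2c(cc1OC)CN(S(=O)(=O)c1ccc(-n3cc(COc4ccc5ccccc5c4)nn3)cc1)CC2`. In an ADME assay on Vero cells (Chlorocebus sabaeus) for cytotoxicity, with a stated time of 4 days (a higher number here means a weaker inhibitor, a lower number a stronger inhibitor), compound 1 gives > 50 ug/mL, which is a limit of the assay and not a number.
Compound 2 `COc1cc2c(cc1OC)CN(S(=O)(=O)c1ccc(-n3cc(COc4ccccc4C)nn3)cc1)CC2`. In this assay compound 2 gives > 50 ug/mL, again a limit.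
Compound 3 `COc1cc2c(cc1OC)CN(S(=O)(=O)c1ccc(-n3cc(COc4ccccc4)nn3)cc1)CC2`. In this assay compound 3 gives > 50 ug/mL, also a limit.

Compound 3 therefore stands where every measured compound stands: at the limit of > 50 ug/mL in this assay, at which 3 of the 3 values shown sit. Compound 4 `COc1cc2c(cc1OC)CN(S(=O)(=O)c1ccc(-n3cc(CO)nn3)cc1)CC2` differs from compound 3 by hydrogen in place of phenyl on an oxygen on a saturated carbon. The measured steps that touch compound 3, a step that the two limits leave unreadable from compound 1 to compound 3 and a step that the two limits leave unreadable from compound 2 to compound 3, cannot be read in size, and neither can a step that the two limits leave unreadable from compound 1 to compound 2. So no direction can be taken from them. Compound 4 is expected to sit at the same limit in this assay, with a step that the limit leaves unreadable from compound 3 to compound 4 as the expected step, and its estimated value is 60 ug/mL (range 30 ug/mL to 120 ug/mL).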

Compound 4, half-maximal inhibitory concentration: > 50 ug/mL
Compound 4 was reported as a limit (the forecaster's own chance of this, stated with the estimate: 85%); the middle value lies beyond the limit too.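

Compound 4 gives only a limit, so none of its steps from compound 1, compound 2 or compound 3 can be read in size: the limit of > 50 ug/mL in this assay, at which 4 of the 4 values shown sit.

On these data alone, whether hydrogen, phenyl, 2-methylphenyl or naphthalen-2-yl on that oxygen makes any difference in this assay stays open.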